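From pyridin-2-yl to 3-hydroxyphenyl on the shared core

The compounds below may be only part of what the source reports. "The series", "measured", "known", "first", "only" and "open" are said of these compounds alone.

Within the data shown here, in a functional assay on HCT-116 cells (Homo sapiens) for antiproliferative activity, read by MTT assay, with a stated time of 24 h (a lower number here means a stronger inhibitor, a higher number a weaker inhibitor), compound 3 `COc1ccc(C(=O)/C=C/c2ccccn2)c2c1C=CC(C)(C)O2` gives 6630 nM, the only exact number among the three measured compounds. Compound 1 `COc1ccc(C(=O)/C=C/c2cccc(F)c2)c2c1C=CC(C)(C)O2` gives only a limit, > 10000 nM. Compound 2 `COc1ccc(C(=O)/C=C/c2ccco2)c2c1C=CC(C)(C)O2` also gives only a limit, > 10000 nM. Compound 4 `COc1ccc(C(=O)/C=C/c2cccc(O)c2)c2c1C=CC(C)(C)O2` differs from compound 3 in one place: 3-hydroxyphenyl in place of pyridin-2-yl on a double-bonded chain carbon bound to a double-bonded chain carbon. Among the measured compounds shown here, two measured steps bear on this change: an at least 1.5-fold lower number from compound 1 to compound 3 (0.17 log units; that floor lies within the scatter) and an at least 1.5-fold lower number from compound 2 to compound 3 (0.17 log units; that floor lies within the scatter). Both sizes are only floors within the scatter, so neither sets a firm size. Compound 1, with its 3-fluorophenyl, is the closest comparison, and its limit of > 10000 nM suggests a weaker result, though no change beyond the scatter is expected. The estimated change is a 1.4-fold higher number from compound 3 to compound 4 (0.13 log units; within the scatter). Compound 4 is expected at about 9000 nM, within an estimated range of 3000 nM to 25000 nM.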

Compound 4, half-maximal inhibitory concentration: > 10000 nM
Compound 4 was reported as a limit (the forecaster's own chance of this, stated with the estimate: 45%); middle value at least 1.1-fold (0.04 log units) away from the limit.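

In this assay, 3-hydroxyphenyl in place of pyridin-2-yl gives an at least 1.5-fold higher number from compound 3 to compound 4 (0.17 log units; that floor lies within the scatter). Among these compounds, the hydrogen-bond donor that 3-hydroxyphenyl brings to this position therefore shows no gain, and compound 3 remains the only compound with an exact number. The steps among compounds 1, 2 and 4, including hydroxy in place of fluoro, cannot be read because these values are limits rather than numbers: the limit of > 10000 nM in this assay, at which 3 of the 4 values shown sit.

From the compounds shown here alone, how far these three compounds lie past that limit stays open. So does whether a 3-aminophenyl group or a carboxylic acid on the phenyl ring would give a lower number here.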